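Chlorine removal on the purine core of compound 2

The source may hold more compounds than are shown below. What is called first, only, known or untested is meant among the compounds shown, and "the series" means these compounds.

Compound 1 `ClCc1ccccc1Cn1cnc2c(Cl)ncnc21`: > 100000 nM
Compound 2 `ClCc1ccc(Cn2cnc3nc(Cl)nc(Cl)c32)cc1`: > 100000 nM
Compound 3 `ClCc1ccc(Cn2cnc3c(Cl)nc(Cl)nc32)cc1`: 7080 nM

Of the compounds shown here, three have been tested in a functional assay on SNB-19 cells (Homo sapiens) for cytotoxicity, read by sulforhodamine B assay, with a stated time of 48 h; a higher number here means a weaker inhibitor of growth, a lower number a stronger inhibitor of growth. Compound 1 gives > 100000 nM in this assay, which is a limit of the assay and not a number. Compound 2 likewise gives > 100000 nM, again a limit and not a number. Only compound 3 gives an actual number in this assay, 7080 nM. Going by the values given here, compound 2 therefore stands at the limit of > 100000 nM in this assay, at which 2 of the 3 values shown sit, so its true value is not known, and no step between measured compounds that differ in one place is available to guide expectation.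

Compound 4 `ClCc1ccc(Cn2cnc3ncnc(Cl)c32)cc1` is not yet measured. It differs from compound 2 by hydrogen in place of chloro on an aromatic carbon, in words: hydrogen in place of chloro on an aromatic carbon. Compound 1 shares the core of compound 4 and also sits at the limit. Compound 4 is therefore expected to remain near the limit of this assay, with a step from compound 2 to compound 4 of a number no higher from compound 2 to compound 4 (the limit leaves the size open) estimated as none beyond the scatter. The estimate for compound 4 in this assay is 100000 nM, with a range from 20000 nM to 300000 nM.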

Compound 4, concentration for total growth inhibition: 3160 nM
Estimate against measurement, compound 4: 32-fold (1.50 log units) above, outside the stated range (below it).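

In this assay, the position between two ring nitrogen atoms proves sensitive: hydrogen in place of chloro on this aromatic carbon gives an at least 31-fold lower number from compound 2 to compound 4 (1.50 log units; beyond the scatter). Going by these compounds alone, this is the first step that can be read, since the earlier compounds offered no pair differing in one place, and it shows that the chloro group at this position is not needed for compound 4 to give a measured value in this assay. Compound 2 gives > 100000 nM, which is a limit of the assay and not a number, so the step sets only a minimum and its full size stays unknown: the limit of > 100000 nM in this assay, at which 2 of the 4 values shown sit.

The compounds shown leave open whether the effect belongs to chloro specifically, as they do not tell how an amine, a methoxy group or a methyl group on this carbon would compare with hydrogen. Within the data shown here, they also leave open whether the same change would produce a step of similar size with the remaining chloro group or the chloromethyl group replaced, since this single pair is the only evidence for it.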